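Methoxy for Fluoro on a Chromone Scaffold

A few compounds are considered here, and "the series" means these few. Any claim that something is new, unique, unknown or untested is made for them only; others in the source may bear on it.

Measured compounds:
- compound 1, `COc1ccc(-c2c(-c3ccc(S(C)(=O)=O)cc3)oc3ccccc3c2=O)cc1`, an assay on isolated protein for inhibition of prostaglandin G/H synthase 1 (Mus musculus), tested at 10 ug/mL; a lower number here means less inhibition, a higher number more inhibition at the concentration tested (going by the name of the read-out): < 5%
- compound 2, `CSc1ccc(-c2c(-c3ccc(S(N)(=O)=O)cc3)oc3ccccc3c2=O)cc1`, 90%
- compound 3, `NS(=O)(=O)c1ccc(-c2oc3ccccc3c(=O)c2-c2ccc(F)cc2)cc1`, 67%

Among the two compounds with a numerical reading, compound 3 stands lowest, with compound 2 nearest and higher. For compound 1 the reading is a limit of the assay rather than a number, (the limit of < 5% in this assay, at which 1 of the 3 values shown sits). Going by the values given here, the one step measured in one place runs a number 23 percentage points lower from compound 2 to compound 3 (beyond the scatter), the change being fluoro in place of methylsulfanyl on an aromatic carbon.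

Compound 4, `COc1ccc(-c2c(-c3ccc(S(N)(=O)=O)cc3)oc3ccccc3c2=O)cc1`, has not yet been measured. It differs from compound 3 as follows: methoxy in place of fluoro on an aromatic carbon. Among the compounds with values here, no measured step covers methoxy in place of fluoro at this position, and the methoxy-bearing compound 1 carries a different group elsewhere, so its limit cannot be carried over. Within the data shown here, the only step in hand, from compound 2 to compound 3, concerns a different group and gives no direction for this change. Compound 4 is therefore expected to remain close to compound 3, with a step of a number 7 percentage points lower from compound 3 to compound 4 (within the scatter) that need not exceed the scatter, and its estimated value is 60%, between 25% and 90%.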

Compound 4, a percentage reported as inhibition, at one concentration (the size of the read-out at that concentration, not a potency): 84%
For compound 4 the middle estimate is 24 percentage points below the measured one, and the stated range covers the measured number.
By their numbers in this assay, from the lowest: compound 3; then compounds 4 and 2 (each within the scatter of the next). At a limit, below all of these: compound 1.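

In this assay, going by these compounds alone, the change from 4-fluorophenyl to 4-methoxyphenyl gives the first measured step for this swap on this aromatic carbon, and the reading moves: the change reads a number 17 percentage points higher from compound 3 to compound 4 (beyond the scatter). Methoxy in place of methylsulfanyl at the same place reads a number 6 percentage points lower from compound 2 to compound 4 (within the scatter), so among the three groups shown here the two that carry a chalcogen atom are not told apart, while fluoro stands apart from both. With the 4-methoxyphenyl held fixed, amino in place of methyl on the sulfonyl sulfur reads a number at least 79 percentage points higher from compound 1 to compound 4 (beyond the scatter), a step that starts from a limit of the assay rather than from a number: the limit of < 5% in this assay, at which 1 of the 4 values shown sits.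

Going by these compounds, what remains open is whether an ethoxy or a longer alkoxy chain, a hydroxyl or an amine at this place would stay with methoxy and methylsulfanyl or fall back towards fluoro. On these data alone, it is also open whether the large step on the sulfonyl sulfur would recur with fluoro or methylsulfanyl on the aromatic ring, or what a carboxylic acid in place of the sulfonamide would give.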